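The source may hold more compounds than are shown below. What is called first, only, known or untested is meant among the compounds shown, and "the series" means these compounds.

Of the compounds shown here, three have so far been measured in an assay for inhibition of alpha-N-acetylgalactosaminidase (Gallus gallus), tested at 1000 uM; a higher number here means more inhibition at the concentration tested (going by the name of the read-out), a lower number less inhibition. Compound 1 `O=C(O)[C@@H]1NCC=C[C@@H]1O` gives 1.3%, and compound 3 `O=C(O)[C@H]1NCC=C[C@H]1O` gives 0.2%; the step of a number 1.1 percentage points lower from compound 1 to compound 3 (within the scatter) is within the usual scatter, and the two are mirror images, (the fact that compounds 1 and 3 differ only in the configuration as drawn). Compound 2 `O=C(O)[C@H]1NC[C@H](O)[C@@H](O)[C@H]1O` gives 31%, the highest of the three, beyond the scatter from both of the others. Compound 4 `O=C(O)[C@@H]1NC[C@H](O)[C@H](O)[C@H]1O` differs from compound 2 only in configuration: the two compounds have the same atoms and bonds and differ only in configuration as drawn: 2 of 4 stereo elements differ; a stereocentre at a saturated ring carbon is drawn S in compound 2 and R in compound 4; a stereocentre at a saturated ring carbon is drawn R in compound 2 and S in compound 4. Among the compounds with values here, the only measured step that resembles this change is the one from compound 1 to compound 3, which stayed within the scatter, though both of those values were near zero. A step of a number 16 percentage points lower from compound 2 to compound 4 (beyond the scatter) is therefore expected, downward and uncertain. Compound 4 is estimated at 15%, expected to lie between 0% and 35%.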

Compound 4, a percentage reported as inhibition, at one concentration (the size of the read-out at that concentration, not a potency): 4.4%
Compound 4: the middle estimate sits 10.6 percentage points above what was measured, and the stated range covers the measured number.
By their numbers in this assay, from the lowest: compounds 3, 1 and 4 (each within the scatter of the next); then compound 2.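

In this assay, a change of configuration alone now gives a step beyond the scatter, a number 26.6 percentage points lower from compound 2 to compound 4 (beyond the scatter), whereas the mirror-image pair of compound 1 and compound 3 stayed within it, with both values near zero. No atom enters or leaves in this step, so the drop belongs to the two changed stereocentres taken together: the fact that compounds 2 and 4 differ only in the configuration as drawn

As far as these compounds go, the two stereocentres changed together, and which of them carries the drop stays open. Also open, from the compounds shown here alone, is whether the number of compound 2 holds when a methyl ester or a primary amide replaces its carboxylic acid.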